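The source may report more compounds than this note shows. Statements on the series, on what has been measured and on what is new or still open speak of the compounds shown alone.

The compounds are compared in an ADME assay for permeability, using PAMPA, with a stated time of 30 min, at pH 7.4; on this read-out lower numbers stand for lower permeability and higher numbers for higher permeability. Compound 1 `COc1ccc(Oc2ccc3c(NCCCNCc4cc(F)ccc4OC)ccnc3c2)cc1` gives 317 10^-6 cm/s in this assay. Compound 2 `COc1cccc(CNCCCNc2ccnc3cc(-c4cc(C(F)(F)F)cc(C(F)(F)F)c4)ccc23)c1O` gives 237 10^-6 cm/s, and compound 3 `COc1ccc(-c2ccc3c(NCCCNCc4ccco4)ccnc3c2)cc1` gives 237 10^-6 cm/s. These three numbers lie within the usual scatter of one another, so compound 1 cannot be set apart from compound 2 or compound 3 on the numbers alone; all three stand at the same level.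

Compound 4 `COc1ccc(F)cc1CNCCCNc1ccnc2cc(-c3ccc(C(C)(C)C)cc3)ccc12` has not yet been measured. It differs from compound 1 in a single place: 4-(tert-butyl)phenyl in place of 4-methoxyphenoxy on an aromatic carbon. Going by the values given here, no measured pair shows exactly this change, so the expectation rests on the three numbers already in hand. Since compound 3, which also carries a phenyl ring at that position, gives 237 10^-6 cm/s, compound 4 is expected to stay at the same level, and the step of a 1.3-fold lower number from compound 1 to compound 4 (0.10 log units; within the scatter) is estimated to be none beyond the scatter. For compound 4 the value is therefore estimated at 250 10^-6 cm/s, with a range from 120 10^-6 cm/s to 450 10^-6 cm/s.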

Compound 4, apparent permeability: 237 10^-6 cm/s
The estimate for compound 4 lay 1.1-fold (0.02 log units) above the measured number; measured number inside the range.
By their numbers in this assay, from the lowest: compounds 2, 3, 4 and 1 (each within the scatter of the next).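

Going by these compounds alone, putting 4-(tert-butyl)phenyl in place of 4-methoxyphenoxy on this aromatic carbon gives a 1.3-fold lower number from compound 1 to compound 4 (0.13 log units; within the scatter) in this assay, the first comparison here of two compounds that differ in one place. The group that leaves has 2 hydrogen-bond acceptors and the group that enters has 0, and even so this read-out does not tell the two compounds apart. Nothing measured here explains why the two stand at the same level.

Still open, going by these compounds, is whether this position would keep that level with an amine, a carboxylic acid or a single fluorine on the aromatic carbon instead of a large ring-bearing group. This single pair also cannot show whether the same change would give the same result with a different group at the far end of the side chain.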